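Swapping Ethoxy for Propyl on the Aryl Ring

A few compounds are considered here, and "the series" means these few. Any claim that something is new, unique, unknown or untested is made for them only; others in the source may bear on it.

Compound 1, `COc1ccccc1N1CCN(CCCNc2ccc(C(=O)N(C)C)cn2)CC1`: 31.6 nM
Compound 2, `COc1ccccc1N1CCN(CCCOc2ccccc2C(=O)N(C)C)CC1`: 31.6 nM
Compound 3, `CCOc1ccccc1N1CCN(CCCNc2ncccc2C(=O)N(C)C)CC1`: 7.94 nM

In a functional assay on aorta for antagonist activity at Alpha-1D adrenergic receptor (Rattus norvegicus) (on this read-out lower numbers stand for tighter binding and higher numbers for weaker binding), compound 3 gives the lowest of the three numbers, and its gap to compound 1 and to compound 2 lies beyond the scatter, so compound 3 is the tightest binder of the three shown. Compound 4, `CCCc1ccccc1N1CCN(CCCNc2ncccc2C(=O)N(C)C)CC1`, is not yet measured. It differs from compound 3 in one place: propyl in place of ethoxy on an aromatic carbon. The rest of the shared core is unchanged. Within the data shown here, no measured pair shows this change, so the step has to be estimated from compound 3 alone. For compound 4 a small loss is expected in this assay, a step of a 2.5-fold higher number from compound 3 to compound 4 (0.40 log units; beyond the scatter) that may stay within the scatter. Compound 4 is estimated at 20 nM, with a range from 5 nM to 80 nM.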

Compound 4, dissociation constant: 31.6 nM
Compound 4: the middle estimate sits 1.6-fold (0.20 log units) below what was measured; measured number inside the range.
By their numbers in this assay, from the lowest: compound 3; then compounds 1, 2 and 4 (each within the scatter of the next).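

In this assay, among these compounds, replacing ethoxy with propyl on this aromatic carbon gives a 4.0-fold higher number from compound 3 to compound 4 (0.60 log units; beyond the scatter), the first measured step at this position, and it is a modest loss of binding. The two groups have the same number of heavy atoms, but propyl has carbon where ethoxy has an oxygen, so a change that keeps this count can still shift the number. Nothing available says what lies behind this loss. On these data alone, what a hydroxyl, an amine or a butyl chain would do on this carbon remains open, as does whether the same swap would give a similar step on another core.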